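Swapping a cyanophenyl group in a cytotoxicity series

A few compounds are considered here, and "the series" means these few. Any claim that something is new, unique, unknown or untested is made for them only; others in the source may bear on it.

In a toxicity assay on MT4 cells (Homo sapiens) for cytotoxicity, read by MTT assay (a lower number here means that less compound is tolerated, a higher number that more compound is tolerated), compound 1 `Cc1cc(-c2ccccc2)ccc1Oc1cc(N)nc(Nc2ccc(C#N)cc2)n1` gives 20000 nM and compound 2 `Cc1cc(-c2ccc(F)cc2)ccc1Oc1cc(N)nc(Nc2ccc(C#N)cc2)n1` gives 20100 nM while compound 3 `Cc1cc(-c2ccccc2C#N)ccc1Oc1cc(N)nc(Nc2ccc(C#N)cc2)n1` gives 28600 nM on the same shared core. Compound 3 thus stands level with the other two, within the scatter of both. The next structure, compound 4 `Cc1cc(-c2ccc(C#N)c(F)c2)ccc1Oc1cc(N)nc(Nc2ccc(C#N)cc2)n1`, carries 4-cyano-3-fluorophenyl in place of the 2-cyanophenyl of compound 3 4-cyano-3-fluorophenyl in place of 2-cyanophenyl on an aromatic carbon on an aromatic carbon. Going by the values given here, three measured steps bear on this change. Fluoro in place of hydrogen gives a 1.0-fold higher number from compound 1 to compound 2 (0.00 log units; within the scatter) and cyano in place of hydrogen gives a 1.4-fold higher number from compound 1 to compound 3 (0.16 log units; within the scatter) while exchanging 4-fluorophenyl for 2-cyanophenyl gives a 1.4-fold higher number from compound 2 to compound 3 (0.15 log units; within the scatter) at the same ring. None of these steps leaves the scatter. Among the compounds with values here, the new group holds both a cyano and a fluoro, a pairing that no measured compound shows. No change beyond the scatter is therefore expected, and the estimated step is a 1.3-fold lower number from compound 3 to compound 4 (0.11 log units; within the scatter) in this assay for now. Compound 4 is expected to give 22000 nM within an estimated range of 10000 nM to 45000 nM on this reading.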

Compound 4, half-maximal cytotoxic concentration: 6600 nM
For compound 4 the middle estimate is 3.3-fold (0.52 log units) above the measured one; measured number below the stated range.
By their numbers in this assay, from the lowest: compound 4; then compounds 1, 2 and 3 (each within the scatter of the next).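

At this position on the shared core, phenyl, 4-fluorophenyl and 2-cyanophenyl all lie within the scatter of one another in this assay, but 4-cyano-3-fluorophenyl moves the number beyond it, with a 4.3-fold lower number from compound 3 to compound 4 (0.64 log units; beyond the scatter), a 3.0-fold lower number from compound 2 to compound 4 (0.48 log units; beyond the scatter) and a 3.0-fold lower number from compound 1 to compound 4 (0.48 log units; beyond the scatter). The position is therefore not indifferent to the group it carries: less compound is tolerated with this group, an outcome that neither the lone fluoro of 4-fluorophenyl nor the lone cyano of 2-cyanophenyl showed. Nothing available explains why this group behaves differently.

The compounds shown leave open whether both substituents are needed, or whether the cyano alone as 4-cyanophenyl or the fluoro alone as 3-fluorophenyl would give the same result. From the compounds shown here alone, how a ring bearing an amine or a carboxylic acid would behave at this position also remains open.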